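The source may report more compounds than this note shows. Statements on the series, on what has been measured and on what is new or still open speak of the compounds shown alone.

Compounds measured in an ADME assay on MT2 cells (Homo sapiens) for cytotoxicity, read by XTT assay, with a stated time of 4 days; on this read-out higher numbers stand for lower toxicity in this test and lower numbers for higher toxicity in this test:
compound 1, `C=CCc1cc(C)c(Oc2ccc([N+](=O)[O-])c(Nc3ccc(C#N)cc3)n2)c(C)c1`: 39700 nM
compound 2, `CC(=O)/C=C/c1cc(C)c(Oc2ccc([N+](=O)[O-])c(Nc3ccc(C#N)cc3)n2)c(C)c1`: > 47900 nM

In this assay compound 1 gives 39700 nM. For compound 2 the value is a limit of the assay rather than a number, > 47900 nM. For the measured compounds named here, compound 2 therefore stands at the limit of > 47900 nM in this assay, at which 1 of the 2 values shown sits, and the one measured step, an at least 1.2-fold higher number from compound 1 to compound 2 (0.08 log units; that floor lies within the scatter), is known only as a floor.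

Compound 3, `Cc1cc(/C=C/C#N)cc(C)c1Oc1ccc([N+](=O)[O-])c(Nc2ccc(C#N)cc2)n1`, differs from compound 2 as follows: cyano in place of acetyl on a double-bonded chain carbon bound to a double-bonded chain carbon. Going by the values given here, the only measured step bears on the same chain, and that step from compound 1 to compound 2 reached just a floor within the scatter; no measured step concerns the cyano group itself. On this basis no step beyond the scatter is expected, and the step of an at least 1.0-fold lower number from compound 2 to compound 3 (0.02 log units; that floor lies within the scatter) is estimated to stay close to where compound 2 stands. Compound 3 is expected to give 45000 nM, in the range 20000 nM to 100000 nM.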

Compound 3, half-maximal cytotoxic concentration: > 100000 nM
Compound 3: no number, only a limit; the forecaster's own chance of this, stated with the estimate: 60%; at least 2.2-fold (0.34 log units) between middle value and limit.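

In this assay, for the compounds shown here, the change from allyl to 2-cyanoethenyl on an aromatic carbon gives the first step at this position that is readable beyond the scatter: an at least 2.5-fold higher number from compound 1 to compound 3 (0.40 log units; beyond the scatter). The earlier change on this carbon, to 2-acetylethenyl, established only a floor within the scatter: an at least 1.2-fold higher number from compound 1 to compound 2 (0.08 log units; that floor lies within the scatter). For compound 3 the value is a limit of the assay and not a number, > 100000 nM, so the true size of the step from allyl may be larger than this floor.

As far as these compounds go, with only a limit for both compound 2 and compound 3, the step between them cannot be read, and it remains open whether cyano or acetyl on the chain gives the higher number. Also open, from the compounds shown here alone, is how this read-out would respond to an amine or a carboxylic acid in place of cyano on the same chain.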